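Trimming the Ethyl Chain on the Core of Compound 1

The source may hold more compounds than are shown below. What is called first, only, known or untested is meant among the compounds shown, and "the series" means these compounds.

Measured compounds:
compound 1 `CCc1nc(-c2ccccc2F)c(C(=O)N2CCN(c3cccc(Cl)c3)CC2)o1` — 139 nM
compound 2 `CCc1nc(-c2ccc(C(C)(C)C)cc2)c(C(=O)N2CCN(c3cccc(OC)c3)CC2)o1` — "not active" (no number reported)
compound 3 `CCc1nc(-c2cccc(F)c2)c(C(=O)N2CCN(c3cccc(Cl)c3)CC2)o1` — 317 nM

In a functional assay on HL-60 cells (Homo sapiens) for inhibition, read by MTT assay, with a stated time of 72 h (on this read-out higher numbers stand for weaker inhibition and lower numbers for stronger inhibition), compound 1 gives 139 nM, the lowest of the two numbers recorded. Its nearest neighbour is compound 3, which gives 317 nM; the step of a 2.3-fold higher number from compound 1 to compound 3 (0.36 log units; beyond the scatter) is modest but beyond the scatter. Compound 2 was reported as "not active" (no number reported), without a number, so it cannot be placed against the other two.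

Compound 4 `Cc1nc(-c2ccccc2F)c(C(=O)N2CCN(c3cccc(Cl)c3)CC2)o1` is the next compound to be tested. It differs from compound 1 by hydrogen in place of methyl on a saturated chain carbon bound to an aromatic carbon. Going by the values given here, none of the measured steps bears directly on this change: the only step that is known concerns the fluorophenyl ring, and neither compound 2 nor compound 3 varies the chain on the core. With nothing to anchor a direction, the cut of a single carbon from the chain is expected to leave the number close to that of compound 1, with no step beyond the scatter, and the expected step is a 1.4-fold higher number from compound 1 to compound 4 (0.16 log units; within the scatter). Compound 4 is therefore estimated at 200 nM in this assay, with a range of 70 nM to 600 nM.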

Compound 4, half-maximal inhibitory concentration: 39.4 nM
Compound 4: middle estimate off by 5.1-fold (0.71 log units), on the high side; the whole stated range lies above it.
By their numbers in this assay, from the lowest: compound 4; then compound 1; then compound 3.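

Ethyl to methyl on the core is the first change at this place among the compounds shown, and in this assay it gives a 3.5-fold lower number from compound 1 to compound 4 (0.55 log units; beyond the scatter) with the fluorophenyl ring and the chlorophenyl piperazine amide left as they are. The chain on the core therefore counts for the number, and the loss of one carbon there gives a step of the same modest grade as the one seen on the fluorophenyl ring, where the shift of the fluorine gives a 2.3-fold higher number from compound 1 to compound 3 (0.36 log units; beyond the scatter) in the same series. No measurement shown accounts for the lower number of compound 4.

With only ethyl and methyl in hand, the compounds shown leave open whether the number keeps falling as the chain shortens, for instance with a bare hydrogen on the core, or whether a longer chain such as propyl, or a cyclopropyl group, continues the rise seen with ethyl. They also leave open whether ethyl to methyl gives a step of the same direction and size with the 3-fluorophenyl group of compound 3 in place of the 2-fluorophenyl group.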